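Methoxy for Chloro at the Far Phenyl of Compound 1

The source may report more compounds than this note shows. Statements on the series, on what has been measured and on what is new or still open speak of the compounds shown alone.

Compound 1 `O=C(NCc1cn(Cc2ccc(C(F)(F)F)cc2)nn1)c1cn(-c2ccccc2)nc1-c1ccc(Cl)cc1` gives 1900 nM in a functional assay on HeLa cells (Homo sapiens) for antiproliferative activity, read by sulforhodamine B assay, with a stated time of 48 h (a higher number here means a weaker inhibitor of growth, a lower number a stronger inhibitor of growth), the higher of the two numbers measured; compound 2 `COc1cc(Cn2cc(CNC(=O)c3cn(-c4ccccc4)nc3-c3ccc(Cl)cc3)nn2)cc(OC)c1OC` gives 100 nM in this assay. Among the compounds with values here, the one measured step, a 19-fold lower number from compound 1 to compound 2 (1.28 log units; beyond the scatter), concerns the group on the saturated chain carbon bound to an aromatic nitrogen, a different place from the one changed here. Compound 3 `COc1ccc(-c2nn(-c3ccccc3)cc2C(=O)NCc2cn(Cc3ccc(C(F)(F)F)cc3)nn2)cc1` differs from compound 1 by methoxy in place of chloro on an aromatic carbon. Within the data shown here, no measured step bears on this change, so compound 3 is expected to show a 1.1-fold higher number from compound 1 to compound 3 (0.02 log units; within the scatter), a step within the scatter. Compound 3 is estimated at 2000 nM, with a range from 600 nM to 7000 nM.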

Compound 3, concentration for 50% growth inhibition: 6200 nM
Compound 3: middle estimate off by 3.1-fold (0.49 log units), on the low side, within the range that was stated.
By their numbers in this assay, from the lowest: compound 2; then compound 1; then compound 3.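

Replacing 4-chlorophenyl with 4-methoxyphenyl gives a 3.3-fold higher number from compound 1 to compound 3 (0.51 log units; beyond the scatter) in this assay, so this position responds to change, and the growth inhibition weakens modestly. Among these two groups, chloro gives the lower number, at least with the 4-(trifluoromethyl)phenyl group in place. No data at hand explain this difference.

On these data alone, it remains open whether the same change would cost as much in compound 2, which carries 3,4,5-trimethoxyphenyl instead. Also open, as far as these compounds go, is how a bromo or an amine at this position would compare with chloro.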